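The source may hold more compounds than are shown below. What is called first, only, known or untested is meant among the compounds shown, and "the series" means these compounds.

The measured compounds and their values:
compound 1, `O=C1N=C(N2N=C(c3ccccc3)CC2c2ccc(Cl)cc2)S/C1=C1/C(=O)Nc2ccccc21`, which in a functional assay on cells (Cancer cell lines, Homo sapiens) for cytotoxicity, read by sulforhodamine B assay, with a stated time of 48 h (a higher number here means a weaker inhibitor of growth, a lower number a stronger inhibitor of growth), gives 500 nM;
compound 2, `CN(C)c1ccc(C2CC(c3ccccc3)=NN2C2=NC(=O)/C(=C3\C(=O)Nc4ccccc43)S2)cc1`, which in this assay gives 3240 nM.

Compound 2 has the highest number of the two. Among the measured compounds shown here, the only other compound, compound 1, sits at a lower number, and that gap, a 6.5-fold higher number from compound 1 to compound 2 (0.81 log units; beyond the scatter), is the single measured step: one group swapped for another on an outer ring.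

Compound 3, `CN(C)c1ccc(C2CC(c3ccccc3)=NN2C2=NC(=O)/C(=C3\C(=O)Nc4ccc(Cl)cc43)S2)cc1`, differs from compound 2 in one place: chloro in place of hydrogen on an aromatic carbon. For the measured compounds named here, this change sits at another site than the one varied between compound 1 and compound 2, so no measured step speaks to it directly, and the one step on record cannot be carried over. With nothing to rest on, the plain expectation is that the step from compound 2 to compound 3 in this assay stays within the scatter: a 1.0-fold lower number from compound 2 to compound 3 (0.01 log units; within the scatter). Compound 3 is therefore estimated at 3200 nM, with a range from 1100 nM to 9500 nM wide enough to allow a real shift in either direction.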

Compound 3, concentration for total growth inhibition: 430 nM
Beside the measured number, compound 3's estimate is 7.4-fold (0.87 log units) above it, and the stated range ends above it.
By their numbers in this assay, from the lowest: compounds 3 and 1 (each within the scatter of the next); then compound 2.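

In this assay the step of a 7.5-fold lower number from compound 2 to compound 3 (0.88 log units; beyond the scatter) shows that a second site responds: a single chloro on an aromatic carbon of the six-membered aromatic ring of carbon only, meta to a fused ring and para to a fused ring, moves the number beyond the scatter towards a stronger inhibitor of growth. The earlier step of a 6.5-fold higher number from compound 1 to compound 2 (0.81 log units; beyond the scatter) concerned only a group on an outer ring and raised the number, so it said nothing about this part of the molecule, and the new step shows that a change here can lower the number even with dimethylamino kept on the outer ring. Nothing shown explains how this chloro produces the shift.

A single replacement of hydrogen at one position cannot show whether the shift is particular to chloro or would also appear with fluoro, bromo or methoxy on the same aromatic carbon. On these data alone, it also remains open whether chloro at this position would lower the number to the same extent with chloro instead of dimethylamino on the outer ring.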